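Swapping the sulfonamide aryl substituent for a sulfone

The source may hold more compounds than are shown below. What is called first, only, known or untested is meant among the compounds shown, and "the series" means these compounds.

The account follows two compounds sharing one core and another compound that has not yet been measured. In an ADME assay on microsomes from liver (Homo sapiens) for metabolic stability, read by LC-MS, with a stated time of 60 min, tested at 10 uM (on this read-out lower numbers stand for a shorter-lived compound and higher numbers for a longer-lived compound), compound 2 `CCN(CC)C(=O)c1ccc(S(=O)(=O)N2CCC[C@@H](C(=O)N3CCN(c4nc(C(C)C)no4)CC3)C2)cc1` gives 0.213 h. Compound 1 `CC(C)c1noc(C2CCN(C(=O)[C@@H]3CCCN(S(=O)(=O)c4ccc(S(=O)(=O)C(C)C)cc4)C3)CC2)n1` gives > 1 h in this assay, which is a limit of the assay and not a number; one of the two values shown sits at that limit (the limit of > 1 h in this assay, at which 1 of the 2 values shown sits). Going by the values given here, compound 2 thus holds the only numerical value in the set. Compound 3 `CC(C)c1noc(N2CCN(C(=O)[C@@H]3CCCN(S(=O)(=O)c4ccc(S(=O)(=O)C(C)C)cc4)C3)CC2)n1` differs from compound 2 by isopropylsulfonyl in place of diethylcarbamoyl on an aromatic carbon. Among the compounds with values here, no measured step between compounds with this single change is available, so the size of the step can only be expected: the author expects an increase beyond the usual scatter, expressed as a 4.7-fold higher number from compound 2 to compound 3 (0.67 log units; beyond the scatter). On that basis compound 3 is estimated to reach 1 h in this assay, with a plausible range from 0.4 h to 2.5 h, and a fair chance that only the limit is reported.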

Compound 3, half-life: > 1 h
Compound 3: a limit, no number; the forecaster's own chance of this, stated with the estimate: 45%; the middle value lies on the limit itself.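

In this assay, going by these compounds alone, isopropylsulfonyl in place of diethylcarbamoyl on an aromatic carbon, para to a large group, gives an at least 4.6-fold higher number from compound 2 to compound 3 (0.67 log units; beyond the scatter), the first single change in this set that can be read at all. Going by these compounds, compound 3 gives > 1 h, which is a limit and not a number, so the step is only a floor and its true size stays unknown. The read-out has little room left for this series: the limit of > 1 h in this assay, at which 2 of the 3 values shown sit.

Within the data shown here, compound 1 and compound 3 both stand at that limit, so the one change in the shared core that divides them cannot be sized. On these data alone, whether a methylsulfonyl, a carboxylic acid or a primary amide on this aromatic carbon would also carry the half-life to the limit remains open.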